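The source may report more compounds than this note shows. Statements on the series, on what has been measured and on what is new or still open speak of the compounds shown alone.

The series rests on a shared core, seen in compound 1 `COc1cc(Nc2n[nH]c(-c3cccnc3Nc3cc(OC)cc(OC)c3)n2)cc(OC)c1`, for which the result in a functional assay on A-431 cells (Homo sapiens), tested at 0.1 uM (a lower number here means less inhibition, a higher number more inhibition at the concentration tested (going by the name of the read-out)), is "not determined" (no result reported). Compound 2 `COc1cccc(Nc2n[nH]c(-c3cccnc3Oc3cc(OC)cc(OC)c3)n2)c1` gives 83% in this assay. Compound 3 `COc1cc(Nc2n[nH]c(-c3cccnc3Oc3cc(OC)cc(OC)c3)n2)cc(OC)c1` gives 87% in this assay, the highest of the two numbers available, though its nearest neighbour, compound 2, lies within the scatter, so the two cannot be ordered. Going by the values given here, the one measured step, methoxy in place of hydrogen on an aromatic carbon, reads a number 4 percentage points higher from compound 2 to compound 3 (within the scatter) and shows that this kind of change leaves the read-out essentially where it was.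

Compound 4 `COc1cccc(CNc2n[nH]c(-c3cccnc3Oc3cc(OC)cc(OC)c3)n2)c1` is the next compound to be examined. Its difference from compound 3 is 3-methoxybenzyl in place of 3,5-dimethoxyphenyl on a nitrogen on an aromatic ring. Among the compounds with values here, no measured step covers an exchange of this kind: the aromatic ring on the nitrogen is moved one carbon further from that nitrogen and one methoxy is removed. The step from compound 2 to compound 3 bears only on the methoxy part of the change and was within the scatter, so it offers no guide to the rest. Compound 4 is therefore expected to give 55%, within 15% to 85%, in this assay, and the expected step is a number 32 percentage points lower from compound 3 to compound 4 (beyond the scatter), with the direction uncertain.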

Compound 4, a percentage reported as inhibition, at one concentration (the size of the read-out at that concentration, not a potency): 32%
The estimate for compound 4 lay 23 percentage points above the measured number; measured number inside the range.
By their numbers in this assay, from the lowest: compound 4; then compounds 2 and 3 (each within the scatter of the next).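

The earlier compounds shown here changed only a methoxy on the aromatic group carried by this nitrogen, and that change left the read-out where it was; the new result shows that this assay does respond to a change at this place. Exchanging 3,5-dimethoxyphenyl for 3-methoxybenzyl gives a number 55 percentage points lower from compound 3 to compound 4 (beyond the scatter) and thus a clear fall, while exchanging 3-methoxyphenyl for 3-methoxybenzyl, with no methoxy added or removed, gives a number 51 percentage points lower from compound 2 to compound 4 (beyond the scatter) as a fall of similar size. Among these three compounds the fall therefore goes with the change from a phenyl to a benzyl group on this nitrogen rather than with the methoxy, although no measurement to hand explains it.

Going by these compounds, it remains open whether a 3,5-dimethoxybenzyl group would behave like 3-methoxybenzyl, and whether a longer chain such as 2-phenylethyl would lower the read-out further or a carboxylic acid on the ring would alter it. Compound 1 has no result to compare, so nothing here shows what an amine link in place of the ring oxygen does in this series.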